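Moving the nitro group on the sulfonyl-bound phenyl ring

The source may report more compounds than this note shows. Statements on the series, on what has been measured and on what is new or still open speak of the compounds shown alone.

Three measured compounds share one core and differ in the group attached to the sulfonyl sulfur. Compound 1 `COc1ccc(-c2c(Br)c(=O)c3c(OC)cc(OC)cc3n2S(=O)(=O)c2ccc(OC)cc2)cc1` also carries a bromine on the core; in a functional assay on SUP-B15 cells (Homo sapiens) for antiproliferative activity, with a stated time of 72 h (a lower number here means that less compound is needed, a higher number that more compound is needed for the effect), compound 1 gives 2920 nM. Compound 2 `COc1ccc(-c2cc(=O)c3c(OC)cc(OC)cc3n2S(=O)(=O)c2ccc(C=O)cc2)cc1` carries a formylphenyl on the sulfur, and in this assay compound 2 reaches > 34400 nM, which is a limit of the measurement and not a number. Compound 3 `COc1ccc(-c2cc(=O)c3c(OC)cc(OC)cc3n2S(=O)(=O)c2ccc([N+](=O)[O-])cc2)cc1` carries a 4-nitrophenyl, and in this assay compound 3 gives 17100 nM. Of the two compounds with a number, compound 3 stands highest; compound 1 sits below it by a gap beyond the usual scatter. For the measured compounds named here, the one step joining two measured compounds is an at least 2.0-fold lower number from compound 2 to compound 3 (0.30 log units; that floor lies within the scatter); its size rests on the limit of > 34400 nM in this assay, at which 1 of the 3 values shown sits, and is only a floor.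

Compound 4 `COc1ccc(-c2cc(=O)c3c(OC)cc(OC)cc3n2S(=O)(=O)c2cccc([N+](=O)[O-])c2)cc1` differs from compound 3 by 3-nitrophenyl in place of 4-nitrophenyl on a sulfonyl sulfur. Going by the values given here, no measured step exchanges one nitrophenyl for another; the single step on record concerns a different group and does not bear directly on this change. With nothing pointing in either direction, compound 4 is expected to stay within the scatter of compound 3, a change of a 1.0-fold lower number from compound 3 to compound 4 (0.00 log units; within the scatter). The estimate for compound 4 in this assay is 17000 nM, with a range from 6000 nM to 48000 nM.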

Compound 4, half-maximal effective concentration: > 39600 nM
Compound 4: only a limit was reported (the forecaster's own chance of this, stated with the estimate: 25%); middle value at least 2.3-fold (0.36 log units) from the limit.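

In this assay, shifting the nitro group on the ring bound to the sulfonyl sulfur is not a silent change, even though compound 3 and compound 4 have the same atoms, joined differently: the record shows an at least 2.3-fold higher number from compound 3 to compound 4 (0.36 log units; beyond the scatter). The earlier compounds shown here differed in which group sat on the ring, so they could say nothing about where on the ring a group sits; this pair shows that, for the nitro group, the change from 4-nitrophenyl to 3-nitrophenyl alone moves the result beyond the usual scatter, towards more compound being needed. Compound 4 has a limit and not a number, so the size of this step is only a floor: the limit of > 39600 nM in this assay, at which 1 of the 4 values shown sits.

The step from compound 2 to compound 4 cannot be read, and with a single pair the finding holds for the nitro group alone. From the compounds shown here alone, it remains open whether an amine or a carboxylic acid on this ring would respond to the same shift, and whether the shift would matter on a core carrying the bromine of compound 1.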